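A few compounds are considered here, and "the series" means these few. Any claim that something is new, unique, unknown or untested is made for them only; others in the source may bear on it.

Measured so far in an in vitro ADME assay on microsomes from liver (Homo sapiens) for pharmacokinetics; on this read-out higher numbers stand for fast clearance and lower numbers for slow clearance:
- Compound 1 `Cc1ccc(S(=O)(=O)N2C=CNC(=O)[C@H]2CC(=O)N[C@H]2CCN(C3CCC3)CC2(C)C)cc1`: 24 mL.min-1.g-1
- Compound 2 `CC1(C)CNCC[C@@H]1NC(=O)C[C@@H]1C(=O)NC=CN1S(=O)(=O)c1ccc(Cl)c(Cl)c1`: < 50 mL.min-1.g-1 (a limit, not a number)
- Compound 3 `Cc1cc(S(=O)(=O)N2C=CNC(=O)[C@H]2CC(=O)N[C@H]2CCNCC2(C)C)c(C)cc1Cl`: 21 mL.min-1.g-1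

Compound 3 stands at 21 mL.min-1.g-1, within the scatter of compound 1 at 24 mL.min-1.g-1. For the measured compounds named here, the one measured step, a step that the limit leaves unreadable from compound 2 to compound 3, concerns the group on a sulfonyl sulfur and gives no size to work from. Compound 4 `Cc1cc(S(=O)(=O)N2C=CNC(=O)[C@H]2CC(=O)N2CCCC(N(C)C)CC2)c(C)cc1Cl` differs from compound 3 elsewhere, on a carbonyl carbon: a group of 10 heavy atoms (8 carbon, 2 nitrogen; one seven-membered non-aromatic ring with 1 hetero atom) in place of a group of 9 heavy atoms (7 carbon, 2 nitrogen; one six-membered non-aromatic ring with 1 hetero atom), on a carbonyl carbon. Going by the values given here, no measured step covers this change, so the two readable numbers are the only guide. No change beyond the scatter is therefore expected in this assay, and the estimated step is a 1.3-fold higher number from compound 3 to compound 4 (0.12 log units; within the scatter). Compound 4 is expected at 28 mL.min-1.g-1, with an estimated range of 12 mL.min-1.g-1 to 70 mL.min-1.g-1.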

Compound 4, intrinsic clearance in microsomes: 64 mL.min-1.g-1
For compound 4 the middle estimate is 2.3-fold (0.36 log units) below the measured one, within the range that was stated.
By their numbers in this assay, from the lowest: compounds 3 and 1 (each within the scatter of the next); then compound 4.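

In this assay the group on the carbonyl carbon proves able to shift the read-out: the seven-membered ring group in place of the six-membered ring group gives a 3.0-fold higher number from compound 3 to compound 4 (0.48 log units; beyond the scatter) and so lies beyond the scatter. The earlier compounds shown here offered no readable step at all. The change is not one of ring size alone, since the entering group has 0 hydrogen-bond donors and the leaving group has 2. Still open, on these data alone, is how an open-chain amine on the same carbonyl carbon would read. Nothing measured here accounts for this rise.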